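The source may report more compounds than this note shows. Statements on the series, on what has been measured and on what is new or still open speak of the compounds shown alone.

Working notes on the series. Going by the values given here, in a functional assay on HeLa cells for antagonist activity at 5-hydroxytryptamine receptor 6 (Homo sapiens), read by cAMP accumulation and immunoassay (on this read-out lower numbers stand for smaller maximal responses and higher numbers for larger maximal responses), compound 1 `O=S(=O)(c1ccc(Cl)cc1)c1cn(C2CCCNC2)c2ncccc12` gives 76%, the higher of the two numbers seen; compound 2 `CCN1CCCC(n2cc(S(=O)(=O)c3ccc(Cl)cc3)c3cccnc32)C1` gives 71%, and the only measured step, a number 5 percentage points lower from compound 1 to compound 2 (within the scatter), concerns the amine nitrogen in a ring. Compound 3 `O=S(=O)(c1ccccc1F)c1cn(C2CCCNC2)c2ncccc12` differs from compound 1 elsewhere: 2-fluorophenyl in place of 4-chlorophenyl on a sulfonyl sulfur. Among the compounds with values here, no measured step touches the group on the sulfonyl sulfur, so nothing here points to a change beyond the scatter; the step is expected as a number 2 percentage points lower from compound 1 to compound 3 (within the scatter). Compound 3 is therefore estimated at 74%, between 58% and 88%.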

Compound 3, largest response reached (reported as Imax), in percent of the reference or control that the assay uses: 100%
Beside the measured number, compound 3's estimate is 26 percentage points below it; measured number outside the range, above it.
By their numbers in this assay, from the lowest: compounds 2 and 1 (each within the scatter of the next); then compound 3.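

In this assay the group on the sulfonyl sulfur proves able to move the maximal response, with 2-fluorophenyl in place of 4-chlorophenyl giving a number 24 percentage points higher from compound 1 to compound 3 (beyond the scatter). The earlier step at the amine nitrogen in a ring, a number 5 percentage points lower from compound 1 to compound 2 (within the scatter), showed no such change. No data shown offer an explanation for this step. The change swaps both the halogen and its ring position, so the compounds shown leave open which of the two carries the step. Neither 4-fluorophenyl nor 2-chlorophenyl on the sulfonyl sulfur is among them, and either would separate the two.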